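This account rests on a few compounds, and the source may have more. Where it says the series, first, only, none or still open, it means among the compounds named here.

Measured in an ADME assay on MT4 cells (Homo sapiens) for cytotoxicity, read by MTT assay, with a stated time of 5 days; on this read-out higher numbers stand for lower toxicity in this test and lower numbers for higher toxicity in this test:
- Compound 1 `CCS(=O)(=O)NC(=O)c1[nH]c2ccc(Cl)cc2c1S(=O)(=O)c1cc(C)cc(C)c1`: > 283000 nM
- Compound 2 `Cc1cc(C)cc(S(=O)(=O)c2c(C(=O)NS(=O)(=O)c3ccc(F)cc3)[nH]c3ccc(Cl)cc23)c1`: > 252000 nM

Both entries are limits of the assay, not numbers.

Compound 2 stands only at a limit, > 252000 nM. Compound 3 `Cc1cc(C)cc(S(=O)(=O)c2c(C(=O)NS(=O)(=O)c3ccc(F)cc3F)[nH]c3ccc(Cl)cc23)c1` differs from it in one place: fluoro in place of hydrogen on an aromatic carbon. A fluoro group replaces a hydrogen on an aromatic carbon, turning 4-fluorophenyl into 2,4-difluorophenyl. Going by the values given here, the one measured step bearing on this, a step that the two limits leave unreadable from compound 1 to compound 2, gives no size to carry over, so no step beyond the scatter is expected in this assay. The expected step is an at least 1.0-fold lower number from compound 2 to compound 3 (0.03 log units; that floor lies within the scatter). Compound 3 is estimated at 230000 nM, with an expected range of 80000 nM to 280000 nM.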

Compound 3, half-maximal cytotoxic concentration: 121000 nM
The estimate for compound 3 lay 1.9-fold (0.28 log units) above the measured number, within the range that was stated.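

In this assay, the fluoro that turns 4-fluorophenyl into 2,4-difluorophenyl gives an at least 2.0-fold lower number from compound 2 to compound 3 (0.31 log units; beyond the scatter), so a single added atom at this place moves the read-out toward higher toxicity in this test, which the earlier pair could not show. Set against ethyl on the sulfonyl sulfur, 2,4-difluorophenyl gives an at least 2.3-fold lower number from compound 1 to compound 3 (0.36 log units; beyond the scatter). The first step has only a floor for its size because compound 2 stands at a limit: the limit of > 252000 nM in this assay, at which 1 of the 3 values shown sits.

Still open, as far as these compounds go, is whether a chloro, a methoxy or an amine at this place would shift the read-out in the same way.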